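Sulfur benzyl series: 3-methoxybenzyl to 2-fluorobenzyl

The source may report more compounds than this note shows. Statements on the series, on what has been measured and on what is new or still open speak of the compounds shown alone.

Measured in a functional assay on BGC-823 cells (Homo sapiens) for antiproliferative activity, read by MTT assay, with a stated time of 24 h; on this read-out lower numbers stand for stronger inhibition and higher numbers for weaker inhibition:
compound 1 `Sc1nnc(-c2ccc3c(c2)OCCO3)n1-c1ccccc1` gives 47000 nM
compound 2 `Clc1ccccc1CSc1nnc(-c2ccc3c(c2)OCCO3)n1-c1ccccc1` gives 17400 nM
compound 3 `COc1cccc(CSc2nnc(-c3ccc4c(c3)OCCO4)n2-c2ccccc2)c1` gives the limit > 100000 nM

Compound 3 stands only as a limit (the limit of > 100000 nM in this assay, at which 1 of the 3 values shown sits), so no number is known for it. Compound 4 `Fc1ccccc1CSc1nnc(-c2ccc3c(c2)OCCO3)n1-c1ccccc1` differs from it (2-fluorophenyl in place of 3-methoxyphenyl on a saturated chain carbon bound to a sulfur) by 2-fluorophenyl in place of 3-methoxyphenyl on a saturated chain carbon bound to a sulfur.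

For the measured compounds named here, three measured steps bear on this change: a 2.7-fold lower number from compound 1 to compound 2 (0.43 log units; beyond the scatter), an at least 2.1-fold higher number from compound 1 to compound 3 (0.32 log units; beyond the scatter) and an at least 5.7-fold higher number from compound 2 to compound 3 (0.75 log units; beyond the scatter). The benzyl group therefore moved the value in both directions. Compound 4 is expected to resemble the 2-chlorophenyl analogue compound 2 (17400 nM), which gives an expected fall of at least modest size toward stronger inhibition. As far as these compounds go, the expected step is an at least 4.0-fold lower number from compound 3 to compound 4 (0.60 log units; beyond the scatter), though its size stays open while only a limit is known at one end. For compound 4 the estimate is 25000 nM (estimated range 10000 nM to 70000 nM).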

Compound 4, half-maximal inhibitory concentration: 18600 nM
Compound 4: middle estimate off by 1.3-fold (0.13 log units), on the high side; the measured number falls inside the stated range.
By their numbers in this assay, from the lowest: compounds 2 and 4 (each within the scatter of the next); then compound 1. At a limit, above all of these: compound 3.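

In this assay, the 2-fluorobenzyl group reads the same as the 2-chlorobenzyl group, with a 1.1-fold higher number from compound 2 to compound 4 (0.03 log units; within the scatter), so fluoro in place of chloro on an aromatic carbon makes no difference that can be told apart here. With a 2.5-fold lower number from compound 1 to compound 4 (0.40 log units; beyond the scatter), a second benzyl group on the sulfur gives a modest gain over the hydrogen. Compound 3 goes against this pattern, and an at least 5.3-fold lower number from compound 3 to compound 4 (0.73 log units; beyond the scatter) leaves the size of the step open, with compound 3 only a limit: the limit of > 100000 nM in this assay, at which 1 of the 4 values shown sits.

Open, as far as these compounds go, is whether the methoxy group alone sets compound 3 apart. Also open, from the compounds shown here alone, is how a longer chain on the sulfur, or an amine on the phenyl ring, would read.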